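The source may report more compounds than this note shows. Statements on the series, on what has been measured and on what is new or still open speak of the compounds shown alone.

Measured compounds in a functional assay on HepG2 cells (Homo sapiens) for cytotoxicity, read by MTT assay, with a stated time of 72 h; a higher number here means a weaker inhibitor, a lower number a stronger inhibitor: compound 1 `Cc1ccc(-n2nc(C(=O)Nc3ccc(Oc4ncnc5[nH]ccc45)cc3)c(C)cc2=O)cc1` gives 7460 nM; compound 2 `Cc1cc(=O)n(-c2ccc(F)cc2)nc1C(=O)Nc1ccc(Oc2ncnc3[nH]ccc23)c(F)c1` gives 12900 nM; compound 3 `Cc1cc(=O)n(-c2cccc(F)c2)nc1C(=O)Nc1ccc(Oc2ncnc3[nH]ccc23)c(F)c1` gives 23100 nM.

Compound 3 holds the highest of the three numbers in this assay; its nearest neighbour is compound 2, and the move a 1.8-fold higher number from compound 2 to compound 3 (0.25 log units; within the scatter) stays within the scatter, while the gap to compound 1 lies beyond it. Compound 4 `Cc1ccc(-n2nc(C(=O)Nc3ccc(Oc4ncnc5[nH]ccc45)c(F)c3)c(C)cc2=O)cc1` is the next step from compound 3: 4-methylphenyl in place of 3-fluorophenyl on an aromatic nitrogen. Among the measured compounds shown here, only one measured step concerns the group on the aromatic nitrogen, and that step, a 1.8-fold higher number from compound 2 to compound 3 (0.25 log units; within the scatter), is small. For the measured compounds named here, compound 1 carries the same 4-methylphenyl as compound 4 but lacks the fluorine on the amide-bearing ring, and its value sits lower than that of compound 3; no single step covers that pair, so its weight is uncertain. For compound 4 the number in this assay is expected to come out modestly lower than for compound 3, as a 2.1-fold lower number from compound 3 to compound 4 (0.32 log units; beyond the scatter), with an estimate of 11000 nM and a range from 4500 nM to 28000 nM.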

Compound 4, half-maximal inhibitory concentration: 18800 nM
Compound 4: middle estimate off by 1.7-fold (0.23 log units), on the low side; the range from low to high includes it.
By their numbers in this assay, from the lowest: compounds 1, 2, 4 and 3 (each within the scatter of the next, the first and the last beyond it).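

On the aromatic nitrogen, 3-fluorophenyl, 4-fluorophenyl and 4-methylphenyl now cannot be told apart in this assay: a 1.2-fold lower number from compound 3 to compound 4 (0.09 log units; within the scatter) and a 1.5-fold higher number from compound 2 to compound 4 (0.16 log units; within the scatter) both stay inside the scatter, so neither the place of the fluoro group nor methyl in place of fluoro registers here. Among the compounds shown here, the one new step beyond the scatter lies away from that group, with fluoro in place of hydrogen on an aromatic carbon (a 2.5-fold higher number from compound 1 to compound 4 (0.40 log units; beyond the scatter)), and it is modest. No measured evidence on the origin of either result is at hand.

From the compounds shown here alone, whether an amine or a carboxylic acid on that phenyl ring, in place of the methyl, would shift the number beyond the scatter remains open. The fluoro step rests on a single pair, so its size with 4-fluorophenyl or 3-fluorophenyl on the nitrogen is also unknown.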